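This account rests on a few compounds, and the source may have more. Where it says the series, first, only, none or still open, it means among the compounds named here.

Compound 1 `O=C(Nc1ncc(Cc2ccc(F)cc2)s1)C1CCCCC1`: > 50000 nM
Compound 2 `O=C(Nc1ncc(C(OCc2ccc3ccccc3c2)c2ccccc2)s1)c1cccs1`: "not toxic" (no number reported)
Compound 3 `CCCCCC(=O)Nc1ncc(C(Oc2ccc3cc(Br)ccc3c2)c2ccc(Cl)cc2)s1`: > 50000 nM

In an ADME assay on HepG2 2.2.15 cells (Homo sapiens) for cytotoxicity (on this read-out higher numbers stand for lower toxicity in this test and lower numbers for higher toxicity in this test), compound 1 reaches only a limit of the test, recorded as > 50000 nM. Compound 2 is described as "not toxic" (no number reported) without any number. Compound 3 likewise reaches only a limit, given as > 50000 nM. Within the data shown here, compound 3 therefore cannot be placed more closely than the limit of > 50000 nM in this assay, at which 2 of the 3 values shown sit, and no counted step between the measured compounds is available.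

Compound 4 `O=C(Nc1ncc(C(Oc2ccc3cc(Br)ccc3c2)c2ccc(Cl)cc2)s1)c1ccc(Cl)nc1` differs from compound 3 in one place: 6-chloropyridin-3-yl in place of pentyl on a carbonyl carbon. From these three results no direction for this change can be read. The expected step of a number no higher from compound 3 to compound 4 (the limit leaves the size open) is none beyond the scatter. Compound 4 is estimated at 50000 nM, within 20000 nM to 100000 nM, most likely again reported only as a limit.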

Compound 4, half-maximal cytotoxic concentration: "not toxic" (no number reported)
The entry for compound 4 holds no number; there is nothing to compare the estimate with.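

No step can be read from compound 3 to compound 4: compound 3 holds only a limit, and compound 4 holds no number. The compounds shown leave open at what concentration any of them becomes cytotoxic in this assay.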